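Extending the Side Chain of Compound 2 by One Carbon

The source may report more compounds than this note shows. Statements on the series, on what has been measured and on what is new or still open speak of the compounds shown alone.

Among the measured compounds shown here, in a functional assay on the whole organism with Rattus norvegicus as the target (on this read-out higher numbers stand for an effect only at larger amounts of compound and lower numbers for an effect already at smaller amounts), compound 2 `CSCn1c(=N)sc2cc(OC(F)(F)F)ccc21` gives 3 mg/kg, the only number recorded in that assay. Compound 1 `N=c1sc2cc(OC(F)(F)F)ccc2n1CCS(=O)(=O)O` reaches only a limit there, > 10 mg/kg. For the measured compounds named here, the single measured step, an at least 3.3-fold lower number from compound 1 to compound 2 (0.52 log units; beyond the scatter), concerns a different kind of change and does not bear on the length of the chain. Compound 3 `CSCCn1c(=N)sc2cc(OC(F)(F)F)ccc21` differs from compound 2 by (methylsulfanyl)methyl in place of methylsulfanyl on a saturated chain carbon bound to an aromatic nitrogen. Going by the values given here, with no measured step speaking to this change, no shift beyond the scatter is expected, and the step is estimated as no change at the digits printed from compound 2 to compound 3 (within the scatter). Compound 3 is therefore expected to give 3 mg/kg, within a range of 1.5 mg/kg to 7 mg/kg.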

Compound 3, dose for half-maximal effect: 1 mg/kg
For compound 3 the middle estimate is 3.0-fold (0.48 log units) above the measured one; the measured number lies below the stated range.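

The change from (methylsulfanyl)methyl to 2-(methylsulfanyl)ethyl is not neutral at this position: in this assay it gives a 3.0-fold lower number from compound 2 to compound 3 (0.48 log units; beyond the scatter), so chain length on the saturated carbon bound to the aromatic nitrogen matters here. With the chain length kept, methylsulfanyl in place of sulfo gives an at least 10-fold lower number from compound 1 to compound 3 (1.00 log units; beyond the scatter). The size of that step is open-ended, since the value of compound 1 is a limit: the limit of > 10 mg/kg in this assay, at which 1 of the 3 values shown sits.

As far as these compounds go, whether a longer chain would lower the number further remains open. So does how an amine or a carboxylic acid at the chain end would compare with methylsulfanyl.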